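Selenium to Sulfur: Expected Shift in Cytotoxicity for Compound 3

The source may report more compounds than this note shows. Statements on the series, on what has been measured and on what is new or still open speak of the compounds shown alone.

In a functional assay on HepG2 cells (Homo sapiens) for cytotoxicity, read by MTT assay, with a stated time of 48 h (on this read-out lower numbers stand for higher toxicity in this test and higher numbers for lower toxicity in this test), compound 2 `C=CCN1C(=O)/C(=C/c2ccccn2)N=C1[Se]C` gives 6620 nM, the lowest of the two numbers recorded so far. Compound 1 `C=CCN1C(=O)/C(=C/c2ccccn2)NC1=[Se]` gives 29800 nM in this assay, a gap that lies beyond the usual scatter. Compound 3 `C=CCN1C(=O)/C(=C/c2ccccn2)N=C1SC` differs from compound 2 by a group of 2 heavy atoms (1 carbon, 1 sulfur; no ring) in place of a group of 2 heavy atoms (1 carbon, 1 selenium; no ring), on a carbon with a double bond to nitrogen. Going by the values given here, no measured pair shows this exchange, so the direction rests on expectation alone: a modest move toward a higher number is anticipated, estimated as a 2.3-fold higher number from compound 2 to compound 3 (0.36 log units; beyond the scatter). Compound 3 is accordingly expected to give about 15000 nM in this assay, within an estimated range from 5000 nM to 45000 nM.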

Compound 3, half-maximal cytotoxic concentration: 56700 nM
Estimate against measurement, compound 3: 3.8-fold (0.58 log units) below; measured number outside the range, above it.
By their numbers in this assay, from the lowest: compound 2; then compounds 1 and 3 (each within the scatter of the next).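

In this assay, going by these compounds alone, putting methylsulfanyl in place of the selenium-bearing group gives an 8.6-fold higher number from compound 2 to compound 3 (0.93 log units; beyond the scatter), the first measured reading of this exchange. The carbon between two ring nitrogen atoms is thus sensitive to this change, even though the groups that leave and enter have the same count of heavy atoms. Nothing available explains the size of this step.

Going by these compounds, whether a methoxy group, an amine or a longer chain on the same carbon would read nearer compound 2 or compound 3 remains open. So does whether this step holds on a core without the allyl group.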